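From an Aryl Thiourea to a Butyl Thiourea

This account rests on a few compounds, and the source may have more. Where it says the series, first, only, none or still open, it means among the compounds named here.

Compound 2 `COc1cc2c(cc1OC)C(=O)C(CC1CCN(C(=S)Nc3cccc(Cl)c3)CC1)C2` was measured in a functional assay on the whole organism (strain Swiss albino) with Mus musculus as the target, in the maximal electroshock model, with a stated time of 0.5 h (a lower number here means that less compound is needed, a higher number that more compound is needed for the effect), and in that test compound 2 gives 300 mg/kg. Going by the values given here, of the two numbers recorded, compound 2 stands at the highest; its only neighbour, compound 1 `COc1cc2c(cc1OC)C(=O)C(CC1CCN(C(=S)Nc3ccc([N+](=O)[O-])cc3)CC1)C2`, gives 30 mg/kg in this assay. The step of a 10-fold higher number from compound 1 to compound 2 (1.00 log units; beyond the scatter) shows that exchanging one substituted phenyl ring for another on the thiourea nitrogen already moves the read-out well beyond the scatter.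

Compound 3 `CCCCNC(=S)N1CCC(CC2Cc3cc(OC)c(OC)cc3C2=O)CC1` differs from compound 2 by butyl in place of 3-chlorophenyl on an amide-type nitrogen. Among the compounds with values here, no measured pair swaps an aromatic ring for a chain at this position, so the single step seen, a 10-fold higher number from compound 1 to compound 2 (1.00 log units; beyond the scatter), bears on it only indirectly: it tells the author that this nitrogen substituent is sensitive to change, but not in which direction a butyl group will move the number. Given that uncertainty, the author expects a step of a 3.0-fold lower number from compound 2 to compound 3 (0.48 log units; beyond the scatter), with a wide range on either side. The author therefore estimates compound 3 at 100 mg/kg, between 30 mg/kg and 300 mg/kg.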

Compound 3, minimum effective dose: 100 mg/kg
Compound 3: middle estimate and measured number agree at the digits printed, within the range that was stated.
By their numbers in this assay, from the lowest: compound 1; then compound 3; then compound 2.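

In this assay compound 3 gives 100 mg/kg with no ring in the group on this amide-type nitrogen, so an aromatic ring at this position is not needed for a measurable effect among these compounds. The steps of a 3.0-fold lower number from compound 2 to compound 3 (0.48 log units; beyond the scatter) and a 3.3-fold higher number from compound 1 to compound 3 (0.52 log units; beyond the scatter) place butyl inside the span set by the two substituted phenyl groups, with 4-nitrophenyl giving the lowest number and 3-chlorophenyl the highest. Going by these compounds alone, the earlier pair showed only that one substituted phenyl ring can differ from another here, whereas these steps show that exchanging a phenyl ring for a chain has no single direction: the number falls when butyl replaces 3-chlorophenyl and rises when it replaces 4-nitrophenyl.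

No measurement is available that accounts for these differences. Still open, on these data alone, is how a longer chain such as octyl, a branched group such as tert-butyl, a saturated ring such as cyclohexyl or an unsubstituted phenyl ring would compare on this nitrogen, and whether a 4-chlorophenyl or 3-nitrophenyl group would separate the effect of the substituent from that of its place on the ring.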